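The source may report more compounds than this note shows. Statements on the series, on what has been measured and on what is new or still open speak of the compounds shown alone.

Among the measured compounds shown here, compound 2 `CCOC(=O)C1=Cc2ccccc2OC1(OCc1cn(-c2ccc(C)cc2)nn1)C(F)(F)F` is one of two compounds measured in a functional assay on DU-145 cells (Homo sapiens) for inhibition, read by MTT assay, with a stated time of 24 h (on this read-out lower numbers stand for stronger inhibition and higher numbers for weaker inhibition), and on that read-out compound 2 gives 30200 nM, the only plain number recorded. Compound 1 `CCOC(=O)C1=Cc2ccccc2OC1(OCc1cc(-c2ccc(OC)cc2)no1)C(F)(F)F` in this assay returns only a limit, > 150000 nM, which is a boundary of the measurement rather than a number. Compound 3 `CCOC(=O)C1=Cc2ccccc2OC1(OCc1cn(-c2ccccc2)nn1)C(F)(F)F` differs from compound 2 by hydrogen in place of methyl on an aromatic carbon. For the measured compounds named here, no step of this kind has been measured here, so the expected change in this assay is a 1.2-fold higher number from compound 2 to compound 3 (0.06 log units; within the scatter), which is within the usual scatter. Compound 3 is therefore estimated at 35000 nM, with a range from 12000 nM to 100000 nM.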

Compound 3, half-maximal inhibitory concentration: > 150000 nM
Compound 3 was reported as a limit (the forecaster's own chance of this, stated with the estimate: 15%); middle value at least 4.2-fold (0.63 log units) away from the limit.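

In this assay the methyl of the 4-methylphenyl group matters: changing it to plain phenyl gives an at least 4.9-fold higher number from compound 2 to compound 3 (0.69 log units; beyond the scatter) on this single pair. Among the compounds shown here, this is the first step read at this position, and it shows that removing one small group can take a compound from a measurable value to a limit. Compound 3 gives only a limit, so the true step may be larger: the limit of > 150000 nM in this assay, at which 2 of the 3 values shown sit. Still open, on these data alone, is whether another group at this place, such as a chlorine atom or an amine, would keep or improve the inhibition.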